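Taking one benzyl group off compound 2

The source may report more compounds than this note shows. Statements on the series, on what has been measured and on what is new or still open speak of the compounds shown alone.

Compound 1 `O[C@@H]1[C@@H](OCc2ccccc2)[C@H](OCc2ccccc2)[C@@H](COCc2ccccc2)O[C@H]1CC1CC1`: > 50000 nM, a limit of the assay
Compound 2 `O[C@@H]1[C@@H](OCc2ccccc2)[C@H](OCc2ccccc2)[C@@H](COCc2ccccc2)O[C@H]1Cc1ccccc1`: 17400 nM

Within the data shown here, in a functional assay on HeLa cells (Homo sapiens) for antiproliferative activity, read by sulforhodamine B assay (a higher number here means a weaker inhibitor of growth, a lower number a stronger inhibitor of growth), compound 2 gives 17400 nM, the only actual number so far. Compound 3 `OC[C@H]1O[C@@H](Cc2ccccc2)[C@H](O)[C@@H](OCc2ccccc2)[C@@H]1OCc1ccccc1` differs from it by one change: hydrogen in place of benzyl on an oxygen on a saturated carbon. That is hydrogen in place of benzyl on an oxygen on a saturated carbon. Among the measured compounds shown here, the one measured step, an at least 2.8-fold lower number from compound 1 to compound 2 (0.45 log units; beyond the scatter), is a different change, phenyl in place of cyclopropyl, and it is only an indirect guide. Losing a benzyl is therefore expected to raise the number modestly in this assay. The expected step is a 1.7-fold higher number from compound 2 to compound 3 (0.24 log units; within the scatter). Compound 3 is estimated at 30000 nM, with an expected range of 12000 nM to 60000 nM.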

Compound 3, concentration for 50% growth inhibition: 38000 nM
Estimate against measurement, compound 3: 1.3-fold (0.10 log units) below; low and high end bracket the measured number.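

In this assay, hydrogen in place of benzyl on this oxygen gives a 2.2-fold higher number from compound 2 to compound 3 (0.34 log units; beyond the scatter), a modest step but beyond the scatter, and the first here with an actual number at both ends. Going from (benzyloxy)methyl to hydroxymethyl thus weakens growth inhibition only modestly and leaves a readable value. Compound 1, by contrast, is given only as a limit: the limit of > 50000 nM in this assay, at which 1 of the 3 values shown sits.

As far as these compounds go, whether an amine or a carboxylic acid at this place would give a lower number remains open. So does the effect of removing the remaining benzyl groups.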